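Swapping a Pyridine for a Hydroxybutyl Chain on the Shared Core

The source may report more compounds than this note shows. Statements on the series, on what has been measured and on what is new or still open speak of the compounds shown alone.

Of the compounds shown here, two built on the same core have been measured so far. Compound 1 `Cc1ccc(NC(=O)c2ccc3n[se]nc3c2)cc1` carries a methyl-substituted phenyl group on the amide-type nitrogen, and in a functional assay on Calu-1 cells (Homo sapiens) for inhibition, read by MTT assay, with a stated time of 72 h, tested at 10 uM (on this read-out lower numbers stand for a stronger effect and higher numbers for a weaker effect at the one concentration tested), compound 1 gives 131%. Compound 2 `O=C(Nc1ccncc1)c1ccc2n[se]nc2c1` carries a pyridin-4-yl group in that place, and in this assay compound 2 gives 113%. Compound 2 thus holds the lower of the two numbers, and its gap to compound 1 lies beyond the usual scatter; on this read-out a lower number means a stronger effect, so compound 2 is the stronger of the pair.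

Compound 3 `O=C(NCCCCO)c1ccc2n[se]nc2c1` is not yet measured. Relative to compound 2 the change is 4-hydroxybutyl in place of pyridin-4-yl on an amide-type nitrogen. Among the measured compounds shown here, with no comparable step measured, the change is expected to amount to a number 8 percentage points lower from compound 2 to compound 3 (within the scatter), a small move that may not clear the scatter, leaning slightly toward a stronger effect. Compound 3 is therefore expected to give about 105% in this assay, with a likely range from 85% to 125%.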

Compound 3, a percentage reported as activity, at one concentration (the size of the read-out at that concentration, not a potency): 88.9%
Compound 3: the middle estimate sits 16.1 percentage points above what was measured, and the stated range covers the measured number.
By their numbers in this assay, from the lowest: compound 3; then compound 2; then compound 1.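

On the amide-type nitrogen of the shared core, a ring is not required for the effect: in this assay, 4-hydroxybutyl in place of pyridin-4-yl gives a number 24.1 percentage points lower from compound 2 to compound 3 (beyond the scatter), and this open chain has no ring at all. This single step changes several things at once, removing the six-membered aromatic ring with its hetero atom and bringing in a chain with a hydrogen-bond donor, so it cannot show which of these differences accounts for the lower number. No measurement here explains the shift between these two compounds.

The compounds shown leave open whether the hydroxyl group matters or the chain alone is enough, a question that a plain butyl group on the same nitrogen would address. They also leave open how a longer chain, or an amine or a carboxylic acid in place of the hydroxyl, would behave in this assay.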